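Aziridine carbonitrile ureas: aryl substituent swap on compound 1

This account rests on a few compounds, and the source may have more. Where it says the series, first, only, none or still open, it means among the compounds named here.

Measured so far:
- compound 1, `CCOC(=O)c1ccc(NC(=O)N2CC2C#N)cc1`: 9700 nM
- compound 2, `N#CC1CN1C(=O)Nc1ccc(Cl)cc1Cl`: 33000 nM
- compound 3, `CCOC(=O)CNC(=O)N1CC1C#N`: 13000 nM

In a functional assay on L1210 cells (Mus musculus) for inhibition, read by MTT assay (a higher number here means a weaker inhibitor, a lower number a stronger inhibitor), compound 1 has the lowest of the three numbers, but compound 3 sits within the scatter of it, so no order between these two can be read. Compound 2 stands beyond the scatter from compound 1, with the higher number. Compound 4, `N#CC1CN1C(=O)Nc1ccc(C(F)(F)F)cc1`, is not yet measured; it differs from compound 1 by trifluoromethyl in place of ethoxycarbonyl on an aromatic carbon. Among the measured compounds shown here, no measured pair shows this change, so the size of the step in this assay is open; a small shift toward a higher number, or none beyond the scatter, is expected. Compound 4 is estimated at 15000 nM, between 5000 nM and 45000 nM. This means an expected step of a 1.5-fold higher number from compound 1 to compound 4 (0.19 log units; within the scatter).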

Compound 4, half-maximal inhibitory concentration: 7100 nM
The estimate for compound 4 lay 2.1-fold (0.32 log units) above the measured number; low and high end bracket the measured number.
By their numbers in this assay, from the lowest: compounds 4, 1 and 3 (each within the scatter of the next); then compound 2.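

In this assay, among the compounds shown here, trifluoromethyl in place of ethoxycarbonyl gives a 1.4-fold lower number from compound 1 to compound 4 (0.14 log units; within the scatter), the first single-place step, and it does not separate the two groups at this aromatic carbon. On this pair, the position accepts a group with no hydrogen-bond acceptors in place of one that carries them, with no change beyond the scatter. No measurement at hand bears on why the two groups read alike. On these data alone, whether an amine or a carboxylic acid on this aromatic carbon would shift the number beyond the scatter remains open.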